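Swapping the selenium-bearing arm for methoxy in a trimethoxyphenyl amide

The source may hold more compounds than are shown below. What is called first, only, known or untested is meant among the compounds shown, and "the series" means these compounds.

Three amides sharing one core have been measured in a functional assay on KYSE-450 cells (Homo sapiens) for inhibition, read by MTT assay, with a stated time of 48 h; a higher number here means a weaker inhibitor, a lower number a stronger inhibitor. Compound 1 `COc1ccc(CN(C(=O)C2CC2)c2cc(OC)c(OC)c(OC)c2)cc1O` gives 80 nM, compound 2 `COc1ccc(CN(C(=O)CCCl)c2cc(OC)c(OC)c(OC)c2)cc1O` gives 110 nM, and compound 3 `COc1ccc(CN(C(=O)C[Se]C#N)c2cc(OC)c(OC)c(OC)c2)cc1O` gives 280 nM, the highest of the three numbers, with steps of a 3.5-fold higher number from compound 1 to compound 3 (0.54 log units; beyond the scatter) and a 2.5-fold higher number from compound 2 to compound 3 (0.41 log units; beyond the scatter) setting it apart, while the step of a 1.4-fold higher number from compound 1 to compound 2 (0.14 log units; within the scatter) stays within the scatter. Compound 4 `COCC(=O)N(Cc1ccc(OC)c(O)c1)c1cc(OC)c(OC)c(OC)c1` differs from compound 3 as follows: a group of 2 heavy atoms (1 carbon, 1 oxygen; no ring) in place of a group of 3 heavy atoms (1 carbon, 1 nitrogen, 1 selenium; no ring), on a saturated chain carbon bound to a carbonyl carbon. The step from compound 2 to compound 3 bears most directly on this change, since it altered the same saturated chain carbon, and its reversal suggests a lower number for compound 4. For compound 4 the estimate is 120 nM in this assay, with a range of 50 nM to 300 nM. That estimate corresponds to an expected step of a 2.3-fold lower number from compound 3 to compound 4 (0.37 log units; beyond the scatter).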

Compound 4, half-maximal inhibitory concentration: 460 nM
Estimate against measurement, compound 4: 3.8-fold (0.58 log units) below, and the stated range ends below it.
By their numbers in this assay, from the lowest: compounds 1 and 2 (each within the scatter of the next); then compounds 3 and 4 (each within the scatter of the next).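

In this assay, putting methoxy on the saturated chain carbon bound to a carbonyl carbon did not bring the number down, as a 1.6-fold higher number from compound 3 to compound 4 (0.22 log units; within the scatter) stays within the scatter and leaves compound 3 and compound 4 unordered. The other two steps, a 4.2-fold higher number from compound 2 to compound 4 (0.62 log units; beyond the scatter) and a 5.8-fold higher number from compound 1 to compound 4 (0.76 log units; beyond the scatter), lie beyond the scatter, so a higher number at this position does not require selenium. No measurement shown explains this result. Going by these compounds, whether a hydroxyl, a dimethylamino group or a longer chain ending in chlorine would give a number nearer those of compound 1 and compound 2 remains open.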